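Adding a second chloro to the weakest quinolinone

The source may report more compounds than this note shows. Statements on the series, on what has been measured and on what is new or still open speak of the compounds shown alone.

Of the compounds shown here, two of one shared core have been tested in a functional assay on SW-620 cells (Homo sapiens) for cytotoxicity, read by MTT assay, with a stated time of 3 days; on this read-out lower numbers stand for an effect already at smaller amounts and higher numbers for an effect only at larger amounts of compound. Compound 1 `O=C1/C(=C/c2ccccc2Cl)c2ccccc2N1c1c(Cl)cccc1Cl` gives 15 ug/mL in this assay. Compound 2 `O=C1/C(=C/c2ccc(Cl)cc2)c2ccccc2N1c1c(Cl)cccc1Cl` gives 100 ug/mL, the highest of the two numbers shown, so its effect appears only at the larger amount. For the measured compounds named here, the single known step connects these two: a 6.7-fold higher number from compound 1 to compound 2 (0.82 log units; beyond the scatter). Compound 3 `O=C1/C(=C/c2ccc(Cl)cc2Cl)c2ccccc2N1c1c(Cl)cccc1Cl` has not yet been measured; it differs from compound 2 by chloro in place of hydrogen on an aromatic carbon, so that compound 3 carries chloro at both the place that compound 1 uses and the place that compound 2 uses. Because a 6.7-fold higher number from compound 1 to compound 2 (0.82 log units; beyond the scatter) shows that losing the chloro at the position of compound 1 raised the number, restoring a chloro there while keeping the other is expected to lower it again, with a step of about a 4.0-fold lower number from compound 2 to compound 3 (0.60 log units; beyond the scatter). For compound 3 the estimated value in this assay is therefore 25 ug/mL, within a range from 10 ug/mL to 70 ug/mL.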

Compound 3, concentration for half-maximal effect: 2 ug/mL
For compound 3 the middle estimate is 13-fold (1.10 log units) above the measured one, and the stated range ends above it.
By their numbers in this assay, from the lowest: compound 3; then compound 1; then compound 2.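

In this assay, chloro in place of hydrogen ortho to a large group on the ring of compound 2 gives a 50-fold lower number from compound 2 to compound 3 (1.70 log units; beyond the scatter) and is the largest step among these compounds. Adding a chloro to compound 1 also helps, with a 7.5-fold lower number from compound 1 to compound 3 (0.88 log units; beyond the scatter) from the single chloro to the 2,4-dichlorophenyl group. The earlier pair showed only that one chloro placement gave a lower number than the other, whereas compound 3 shows that the two placements together give a lower number than either alone.

The data offer no measured explanation for this result. As far as these compounds go, whether a different group at the same place, such as methoxy or an amine, would lower the number as chloro does remains open.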